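A few compounds are considered here, and "the series" means these few. Any claim that something is new, unique, unknown or untested is made for them only; others in the source may bear on it.

Measured so far in a functional assay on HT-29 cells (Homo sapiens) for cytotoxicity, read by fluorescence and resazurin assay, with a stated time of 48 h (on this read-out lower numbers stand for stronger inhibition and higher numbers for weaker inhibition), each value a limit of the assay rather than a number:
Compound 1 `COc1cc(/C=C/c2cc(/C=C/c3cc(OC)c(OC)c(OC)c3)nc(OCCCCBr)n2)cc(OC)c1OC`: > 20000 nM.
Compound 2 `COc1cc(/C=C/c2cc(/C=C/c3cc(OC)c(OC)c(OC)c3)nc(OCCCCCBr)n2)cc(OC)c1OC`: > 20000 nM.
Compound 3 `BrCCCCCCOc1nc(/C=C/c2ccccc2)cc(/C=C/c2ccccc2)n1`: > 20000 nM.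

All three values sit at the limit of > 20000 nM in this assay, at which 3 of the 3 values shown sit. From compound 2 to compound 1 the change is bromo in place of bromomethyl on a saturated chain carbon, four bonds along the chain from an oxygen on an aromatic ring, and the step it made is a step that the two limits leave unreadable from compound 2 to compound 1. Compound 3 carries a different core from compound 2; the difference between the two cores is not broken down here. Compound 4 `BrCCCCCOc1nc(/C=C/c2ccccc2)cc(/C=C/c2ccccc2)n1` differs from compound 3 by bromo in place of bromomethyl on a saturated chain carbon, five bonds along the chain from an oxygen on an aromatic ring, the same kind of change as from compound 2 to compound 1, but five bonds along the chain from the oxygen rather than four. Resting on compound 2 and compound 1 both sitting at the limit of > 20000 nM in this assay, at which 3 of the 3 values shown sit, the step expected in this assay is a step that the limit leaves unreadable from compound 3 to compound 4. Compound 4 is expected in this assay at 30000 nM, most likely again only a limit.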

Compound 4, half-maximal inhibitory concentration: > 20000 nM
Compound 4: no number, only a limit (the forecaster's own chance of this, stated with the estimate: 85%); the middle value is on the limit's open side.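

No step can be read from compound 3 to compound 4, because both values are limits of the assay: the limit of > 20000 nM in this assay, at which 4 of the 4 values shown sit. The compounds shown leave open whether chain length or core alters cytotoxicity at all.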